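The source may report more compounds than this note shows. Statements on the series, on what has been measured and on what is new or still open speak of the compounds shown alone.

Of the compounds shown here, three sharing one core have been measured in a functional assay for inhibition, with Homo sapiens as the target (a higher number here means a weaker inhibitor, a lower number a stronger inhibitor), and they differ only in the group on a saturated chain carbon bound to an oxygen on an aromatic ring. Compound 1 `CC(C)(C)Sc1c(CC(C)(C)C(=O)O)n(Cc2ccc(Cl)cc2)c2ccc(OCc3ccc4cc(F)c(F)cc4n3)cc12` gives 7 nM, compound 2 `CC(C)(C)Sc1c(CC(C)(C)C(=O)O)n(Cc2ccc(Cl)cc2)c2ccc(OCc3ccc4cnccc4n3)cc12` gives 3 nM, and compound 3 `CC(C)(C)Sc1c(CC(C)(C)C(=O)O)n(Cc2ccc(Cl)cc2)c2ccc(OCc3cccc(Cl)n3)cc12` gives 3 nM. Compound 3 therefore shares the lowest number with compound 2, while compound 1 stands higher.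

Compound 4 `CC(C)(C)Sc1c(CC(C)(C)C(=O)O)n(Cc2ccc(Cl)cc2)c2ccc(OCc3cccs3)cc12` keeps the core and has thiophen-2-yl in place of 6-chloropyridin-2-yl on a saturated chain carbon bound to an oxygen on an aromatic ring.

All three measured steps exchange a group at this same place, so all three bear on the change. Two are modest, a 2.3-fold lower number from compound 1 to compound 2 (0.37 log units; beyond the scatter) and a 2.3-fold lower number from compound 1 to compound 3 (0.37 log units; beyond the scatter), and the third, no change at the digits printed from compound 2 to compound 3 (within the scatter), lies within the scatter. So far, then, quite different groups have moved the number only a little. Among the compounds with values here, none of the measured groups, however, is a five-membered ring or carries sulfur, so there is no direct precedent for thiophen-2-yl. A small step at most is expected in this assay, and any movement is more likely upward, since compound 3 already sits at the low end of the range. The expected change is a 1.3-fold higher number from compound 3 to compound 4 (0.12 log units; within the scatter). For compound 4 the estimate is 4 nM, with an expected range of 2 nM to 12 nM.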

Compound 4, half-maximal inhibitory concentration: 4 nM
The estimate for compound 4 equals the measured number at the digits printed; the range from low to high includes it.
By their numbers in this assay, from the lowest: compounds 2, 3, 4 and 1 (each within the scatter of the next, the first and the last beyond it).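

Thiophen-2-yl shows that a five-membered aromatic ring carrying sulfur can take this place in this assay without moving the number beyond the scatter: the change gives a 1.3-fold higher number from compound 3 to compound 4 (0.12 log units; within the scatter) and, against the two-ring group of compound 2, a 1.3-fold higher number from compound 2 to compound 4 (0.12 log units; within the scatter). Even against the largest group shown, with 12 heavy atoms, the result is a 1.8-fold lower number from compound 1 to compound 4 (0.24 log units; within the scatter). The tolerance seen among the six-membered aromatic rings therefore extends to a smaller ring with a different hetero atom, and compound 4 cannot be separated from any of the other three, even though compound 1 stands beyond the scatter from compound 2 and compound 3.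

Nothing given here explains why such different groups yield such similar numbers. Every group shown at this place is aromatic, so it remains open whether the same tolerance would hold for an amine, a carboxylic acid or a longer saturated carbon chain on the saturated chain carbon bound to an oxygen on an aromatic ring.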